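This account rests on a few compounds, and the source may have more. Where it says the series, first, only, none or still open, it means among the compounds named here.

Measured so far in a functional assay on A549 cells (Homo sapiens) for antiproliferative activity, read by MTT assay, with a stated time of 72 h; a higher number here means a weaker inhibitor, a lower number a stronger inhibitor:

Compound 1, `COc1cc(-n2cnc3ccc(-c4cccc(N)c4)cc32)cc(OC)c1OC`: 640 nM
Compound 2, `COc1cccc(-c2ccc3ncn(-c4cc(OC)c(OC)c(OC)c4)c3c2)c1`: 3180 nM
Compound 3, `COc1ccccc1-c1ccc2ncn(-c3cc(OC)c(OC)c(OC)c3)c2c1`: 4320 nM

Among these three numbers, compound 2 stands second highest. Its nearest neighbour is compound 3, separated by a 1.4-fold higher number from compound 2 to compound 3 (0.13 log units; within the scatter), a gap that lies within the scatter. Its furthest neighbour is compound 1, and the step of a 5.0-fold higher number from compound 1 to compound 2 (0.70 log units; beyond the scatter) goes beyond the scatter.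

Compound 4, `COc1cc(-n2cnc3ccc(-c4ccc(Cl)cc4Cl)cc32)cc(OC)c1OC`, has not yet been measured. It differs from compound 2 in one place: 2,4-dichlorophenyl in place of 3-methoxyphenyl on an aromatic carbon.

For the measured compounds named here, two measured steps touch compound 2. The step of a 5.0-fold higher number from compound 1 to compound 2 (0.70 log units; beyond the scatter) shows that replacing amino with methoxy moved the number modestly, while a 1.4-fold higher number from compound 2 to compound 3 (0.13 log units; within the scatter) shows that relocating the methoxy did not move it beyond the scatter. Neither step involves a dichlorophenyl, so the direction for compound 4 is uncertain. The expected step for compound 4 is therefore a 1.1-fold higher number from compound 2 to compound 4 (0.04 log units; within the scatter), essentially no change beyond the scatter, with a wide range. The estimated value for compound 4 is 3500 nM, expected between 1200 nM and 10000 nM.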

Compound 4, half-maximal inhibitory concentration: > 10000 nM
Compound 4: a limit, no number (the forecaster's own chance of this, stated with the estimate: 10%); middle value at least 2.8-fold (0.45 log units) away from the limit.
By their numbers in this assay, from the lowest: compound 1; then compounds 2 and 3 (each within the scatter of the next). At a limit, above all of these: compound 4.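

In this assay compound 4 gives > 10000 nM, which is a limit of the assay and not a number. Even so, the steps can be read as minimum sizes: an at least 3.1-fold higher number from compound 2 to compound 4 (0.49 log units; beyond the scatter), an at least 2.3-fold higher number from compound 3 to compound 4 (0.36 log units; beyond the scatter) and an at least 15-fold higher number from compound 1 to compound 4 (1.19 log units; beyond the scatter). Moving the methoxy had shown no change beyond the scatter, so this position could have seemed forgiving among methoxyphenyl groups, but 2,4-dichlorophenyl in place of either methoxyphenyl moves the number beyond the scatter, and the activity falls further still from the aminophenyl of compound 1.

The compounds shown leave open whether a phenyl carrying a single chlorine would behave like compound 4, and how far past the limit compound 4 lies. They also leave open whether a hydroxyl or a carboxylic acid on this phenyl ring would match the amino group of compound 1.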